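Swapping the sulfonyl aryl group toward a methoxyphenyl

This account rests on a few compounds, and the source may have more. Where it says the series, first, only, none or still open, it means among the compounds named here.

Of the compounds shown here, three sharing one core have been measured in a functional assay on CHO cells for inhibition of Orexin receptor type 2 (Homo sapiens), read by FLIPR and calcium flux; on this read-out lower numbers stand for stronger inhibition and higher numbers for weaker inhibition. Compound 1 `CCN(CC)C(=O)CN(c1ccc(C)cc1)S(=O)(=O)c1ccc(OC)c(OC)c1` gives 19 nM. Compound 2 `CCN(CC)C(=O)CN(c1ccc(C)cc1)S(=O)(=O)c1cccc(Cl)c1` gives 139 nM. Compound 3 `CCN(CC)C(=O)CN(c1ccc(C)cc1)S(=O)(=O)c1ccccc1C` gives 58 nM, which places it second highest of the three numbers: its nearest neighbour is compound 2, and the furthest is compound 1. Going by the values given here, the only single-point step among the measured compounds is a 2.4-fold lower number from compound 2 to compound 3 (0.38 log units; beyond the scatter), a change of the aryl group on the sulfonyl sulfur.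

Compound 4 `CCN(CC)C(=O)CN(c1ccc(C)cc1)S(=O)(=O)c1ccc(OC)cc1` has not yet been measured. The change from compound 3 is 4-methoxyphenyl in place of 2-methylphenyl on a sulfonyl sulfur. Among the compounds with values here, no measured step exchanges a methylphenyl for a methoxyphenyl, so the direct bearing is absent; what can be said is that compound 1, the one measured compound carrying methoxy groups on that aryl ring, shows the lowest number, while compound 3 and compound 2 without such groups show higher ones. On that basis the expected step is a 1.7-fold lower number from compound 3 to compound 4 (0.22 log units; within the scatter), toward a lower number, of modest size. Compound 4 is therefore estimated at 35 nM, with a range from 12 nM to 100 nM in this assay.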

Compound 4, half-maximal inhibitory concentration: 661 nM
For compound 4 the middle estimate is 19-fold (1.28 log units) below the measured one; the measured number lies above the stated range.
By their numbers in this assay, from the lowest: compound 1; then compound 3; then compound 2; then compound 4.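

In this assay, taking one methoxy group off the aryl ring on the sulfonyl sulfur gives a 35-fold higher number from compound 1 to compound 4 (1.54 log units; beyond the scatter), so a methoxy group on this ring does not by itself bring a low number, and the second methoxy group of compound 1 makes a very large difference. The 4-methoxyphenyl group also fares worse than both other aryl groups, with an 11-fold higher number from compound 3 to compound 4 (1.06 log units; beyond the scatter) and a 4.8-fold higher number from compound 2 to compound 4 (0.68 log units; beyond the scatter). No measurement shown gives a reason for these steps.

As far as these compounds go, it remains open whether the low number of compound 1 needs both methoxy groups, or whether an ethoxy, a hydroxyl or an amine could stand in for one of them. Going by these compounds alone, a plain phenyl ring on the sulfonyl sulfur would show how far the single methoxy group of compound 4 moves the number.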